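The compounds below may be only part of what the source reports. "The series", "measured", "known", "first", "only" and "open" are said of these compounds alone.

Compound 1 `CCCCc1ccc(-c2c(C)[nH]c(=O)n2C)cc1` gives 10700 nM in a functional assay on brain (Rattus norvegicus, strain Wistar) for inhibition; a higher number here means a weaker inhibitor, a lower number a stronger inhibitor. Compound 2 `Cc1[nH]c(=O)n(C)c1-c1ccc(CC(C)C)cc1` carries isopropyl in place of propyl on a saturated chain carbon bound to an aromatic carbon and in this assay compound 2 gives 7800 nM, a step of a 1.4-fold lower number from compound 1 to compound 2 (0.14 log units; within the scatter). Compound 3 `CCCCCOc1ccc(-c2c(C)[nH]c(=O)n2C2CCCCC2)cc1` has a core whose difference from compound 1 is not broken down here; in this assay compound 3 gives 9100 nM. Compound 4 `Cc1[nH]c(=O)n(C2CCCCC2)c1-c1ccc(OCCC(C)C)cc1` shows the same kind of change as before: isopropyl in place of propyl on a saturated chain carbon, two bonds along the chain from an oxygen on an aromatic ring. The places are not identical, since the earlier change sat on a saturated chain carbon bound to an aromatic carbon, whereas here it sits on a saturated chain carbon, two bonds along the chain from an oxygen on an aromatic ring. Because a 1.4-fold lower number from compound 1 to compound 2 (0.14 log units; within the scatter) stayed within the scatter, a step of about a 1.1-fold lower number from compound 3 to compound 4 (0.06 log units; within the scatter) is expected. Compound 4 is estimated at 8000 nM, between 4000 nM and 16000 nM.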

Compound 4, half-maximal inhibitory concentration: 7200 nM
Beside the measured number, compound 4's estimate is 1.1-fold (0.05 log units) above it; the measured number falls inside the stated range.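

Putting isopropyl in place of propyl on the chain of compound 3 gives, in this assay, a 1.3-fold lower number from compound 3 to compound 4 (0.10 log units; within the scatter). The swap reads alike on the two cores, and the two steps cannot be told apart: the same change on two cores in this assay, a 1.4-fold lower number (0.14 log units; within the scatter) from compound 1 to compound 2 and a 1.3-fold lower number (0.10 log units; within the scatter) from compound 3 to compound 4, 1.1-fold (0.04 log units) apart, within the scatter of two such steps. So on these two cores the swap leaves the number within the usual scatter of repeated measurements, but two pairs, with the change at different places on the chain, show no real gain and cannot predict its effect on a third core.

Still open, from the compounds shown here alone, is whether a different group at the end of this chain, such as an amine, a carboxylic acid or a longer chain, would move the number beyond that scatter.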